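Swapping the aryl ketone on a pyrazole chalcone

The source may hold more compounds than are shown below. What is called first, only, known or untested is meant among the compounds shown, and "the series" means these compounds.

The three measured compounds share one core, and differ only in the aromatic ring attached to the carbonyl carbon. In a functional assay on BT-549 cells (Homo sapiens) for inhibition, read by sulforhodamine B assay, with a stated time of 48 h (a lower number here means a stronger inhibitor of growth, a higher number a weaker inhibitor of growth), compound 1 `COc1cc(-c2cc(/C=C/C(=O)c3ccc(N)cc3)[nH]n2)cc(OC)c1OC` gives 1380 nM, compound 2 `COc1ccc(C(=O)/C=C/c2cc(-c3cc(OC)c(OC)c(OC)c3)n[nH]2)cc1` gives 1860 nM, and compound 3 `COc1ccc(C(=O)/C=C/c2cc(-c3cc(OC)c(OC)c(OC)c3)n[nH]2)cc1OC` gives 1440 nM. Compound 3 thus stands second highest of the three, though all three numbers lie within the scatter of one another: the steps of a 1.3-fold higher number from compound 1 to compound 2 (0.13 log units; within the scatter), a 1.0-fold higher number from compound 1 to compound 3 (0.02 log units; within the scatter) and a 1.3-fold lower number from compound 2 to compound 3 (0.11 log units; within the scatter) are all too small to count.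

Compound 4 `COc1cc(-c2cc(/C=C/C(=O)c3ccc(F)c(F)c3)[nH]n2)cc(OC)c1OC` is not yet measured. It differs from compound 3 at the ring on the carbonyl carbon: 3,4-difluorophenyl in place of 3,4-dimethoxyphenyl on a carbonyl carbon.

The three measured steps all concern this same ring, and none moved the number beyond the scatter, whether an amino, a methoxy or a hydrogen was exchanged. Fluorine has not been tried in this position, so the data give no direct guide, but the ring has so far accepted every change without effect. In this assay compound 4 is therefore expected to stay close to compound 3, with the step of a 1.0-fold higher number from compound 3 to compound 4 (0.02 log units; within the scatter) estimated to lie within the scatter. The estimate for compound 4 is 1500 nM, within a range from 600 nM to 4000 nM.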

Compound 4, concentration for 50% growth inhibition: 4110 nM
Compound 4: the middle estimate sits 2.7-fold (0.44 log units) below what was measured, outside the stated range (above it).
By their numbers in this assay, from the lowest: compounds 1, 3 and 2 (each within the scatter of the next); then compound 4.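

Among these compounds, the ring on the carbonyl carbon is less forgiving than the first three compounds suggested: in this assay, 3,4-difluorophenyl in place of 3,4-dimethoxyphenyl gives the only kind of change here that goes beyond the scatter (a 2.9-fold higher number from compound 3 to compound 4 (0.46 log units; beyond the scatter)). The same holds when the difluorophenyl ring replaces the 4-methoxyphenyl ring (a 2.2-fold higher number from compound 2 to compound 4 (0.34 log units; beyond the scatter)) or the 4-aminophenyl ring (a 3.0-fold higher number from compound 1 to compound 4 (0.47 log units; beyond the scatter)), so the steps are modest, but compound 4 is the weakest inhibitor of growth of the four. Amino and methoxy groups on this ring thus give numbers within the scatter of one another, while the two fluorines set compound 4 apart, and no measurement at hand explains this difference.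

Still open, on these data alone, is whether the step comes from the arrival of the fluorines or from the departure of the methoxy groups, a question that an unsubstituted phenyl ring or a 4-fluorophenyl ring at the same place could help to settle. A 3,4-dichlorophenyl ring would also show whether the higher number extends to another halogen or belongs to fluorine alone.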